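A Fluorine-for-Methyl Exchange on the Benzyl Arm

The compounds below may be only part of what the source reports. "The series", "measured", "known", "first", "only" and "open" are said of these compounds alone.

Compound 1 `CNC(=O)c1cc(C(=O)NC2CC2)cn(Cc2ccc(C)cc2)c1=O`: 3.5
Compound 2 `CNC(=O)c1cc(C(=O)NC2CCC2)cn(Cc2cccnc2)c1=O`: 1.8

In a physicochemical assay for lipophilicity, at pH 7.4 (on this read-out higher numbers stand for higher lipophilicity and lower numbers for lower lipophilicity), compound 1 gives 3.5, the higher of the two numbers; compound 2 gives 1.8, a gap beyond the usual scatter. Compound 3 `CNC(=O)c1cc(C(=O)NC2CC2)cn(Cc2ccccc2F)c1=O` differs from compound 1 in one place: 2-fluorophenyl in place of 4-methylphenyl on a saturated chain carbon bound to an aromatic nitrogen. Among the measured compounds shown here, no measured pair shows this exchange, so the expectation rests on compound 1 alone. A small downward step is expected, a number 0.40 log units lower from compound 1 to compound 3 (beyond the scatter), close to the scatter of this assay. Compound 3 is therefore estimated at 3.1, within a range from 2.7 to 3.5.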

Compound 3, distribution coefficient: 3
Estimate against measurement, compound 3: 0.10 log units above; the range from low to high includes it.
By their numbers in this assay, from the lowest: compound 2; then compound 3; then compound 1.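

In this assay, among the compounds shown here, the change from 4-methylbenzyl to 2-fluorobenzyl gives the first one-place step in this set, a number 0.50 log units lower from compound 1 to compound 3 (beyond the scatter), showing that this position on a saturated chain carbon bound to an aromatic nitrogen responds to an exchange between two groups of equal heavy-atom count. Nothing independent bears on why the step has this size. On these data alone, whether the step belongs to the arrival of the fluorine or the departure of the methyl stays open. So does the reading for a plain phenyl, 2-methylphenyl or 4-fluorophenyl at this place.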